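A few compounds are considered here, and "the series" means these few. Any claim that something is new, unique, unknown or untested is made for them only; others in the source may bear on it.

Working notes on the urea series. Compound 1 `CN1CCN(Cc2ccc(NC(=O)Nc3ccc4ncnc(Nc5ccc(F)c(Cl)c5)c4c3)cc2)CC1` gives 3480 nM in a functional assay on A549 cells (Homo sapiens) for antiproliferative activity, read by MTT assay, with a stated time of 72 h; on this read-out lower numbers stand for stronger inhibition and higher numbers for weaker inhibition. Compound 2 `CCN(CC)Cc1ccc(NC(=O)Nc2ccc3ncnc(Nc4cccc(C(F)(F)F)c4)c3c2)cc1` gives 2070 nM, the lowest number of the three, though compound 1 and compound 3 both lie within the scatter of it. Compound 3 `C#Cc1cccc(Nc2ncnc3ccc(NC(=O)Nc4ccc(CN(CC)CC)cc4)cc23)c1` gives 2250 nM; the step of a 1.1-fold higher number from compound 2 to compound 3 (0.04 log units; within the scatter) shows that a change at the aniline end left the read-out unmoved. Compound 4 `CN1CCN(CCNC(=O)Nc2ccc3ncnc(Nc4cccc(C(F)(F)F)c4)c3c2)CC1` carries 2-(4-methylpiperazin-1-yl)ethyl in place of 4-((diethylamino)methyl)phenyl on an amide-type nitrogen. For the measured compounds named here, no measured pair isolates this change: the step from compound 2 to compound 3 touches the other end of the molecule, and compound 1 differs from compound 4 in two places. The estimate therefore stays close to compound 2 with a wide margin, a 1.9-fold higher number from compound 2 to compound 4 (0.29 log units; within the scatter). Compound 4 is expected to give 4000 nM, between 1200 nM and 15000 nM.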

Compound 4, half-maximal inhibitory concentration: > 10000 nM
Compound 4: a limit, no number (the forecaster's own chance of this, stated with the estimate: 10%); at least 2.5-fold (0.39 log units) between middle value and limit.
By their numbers in this assay, from the lowest: compounds 2, 3 and 1 (each within the scatter of the next). At a limit, above all of these: compound 4.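

At the amide-type nitrogen the read-out does move, unlike the ethynyl for trifluoromethyl change at the aniline end: with 2-(4-methylpiperazin-1-yl)ethyl in place of 4-((diethylamino)methyl)phenyl the result is an at least 4.8-fold higher number from compound 2 to compound 4 (0.68 log units; beyond the scatter). Compound 4 stands at a limit, > 10000 nM, and not at a number. The size of this step is set only by that limit: the limit of > 10000 nM in this assay, at which 1 of the 4 values shown sits.

Going by these compounds, the aromatic ring and the amine change together here, and which of them carries the step stays open. A 2-(diethylamino)ethyl chain on the same nitrogen would separate the two.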